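2-Hydroxyethyl replaces isopropyl on the ring nitrogen

The source may hold more compounds than are shown below. What is called first, only, known or untested is meant among the compounds shown, and "the series" means these compounds.

Of the compounds shown here, three have been measured in an assay on isolated protein (urine) for inhibition of Myeloperoxidase (Homo sapiens), read by spectrophotometry; a higher number here means a weaker inhibitor, a lower number a stronger inhibitor. Compound 1 `CCCCCn1nc2ccccc2c1OC` gives 3880 nM in this assay. Compound 2 `CCCCCCCCn1nc2ccccc2c1OCC` reaches only the limit of this assay, > 10000 nM, which is a limit and not a number. Compound 3 `CC(C)n1[nH]c2ccccc2c1=O` gives 660 nM in this assay and so stands lowest of the two numbers shown; its nearest neighbour is compound 1, whose number is higher by a margin beyond the usual scatter. The value of compound 2, being a limit, allows no comparison of size.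

Compound 4 `O=c1c2ccccc2[nH]n1CCO` has not yet been measured in this assay. It differs from compound 3 in one place: 2-hydroxyethyl in place of isopropyl on an aromatic nitrogen. For the measured compounds named here, no measured step between two compounds lets the size of such a change be read directly, and nothing in the data shows how either group acts.

The step from compound 3 to compound 4 is therefore expected to be modest, a 2.3-fold higher number from compound 3 to compound 4 (0.36 log units; beyond the scatter), with a weakening more likely than a gain. Compound 4 is estimated to give 1500 nM in this assay, with a plausible range from 400 nM to 6000 nM.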

Compound 4, half-maximal inhibitory concentration: 2470 nM
Beside the measured number, compound 4's estimate is 1.6-fold (0.22 log units) below it; the range from low to high includes it.
By their numbers in this assay, from the lowest: compound 3; then compounds 4 and 1 (each within the scatter of the next). At a limit, above all of these: compound 2.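

In this assay, for the compounds shown here, the exchange of isopropyl for 2-hydroxyethyl on the aromatic nitrogen gives the first direct reading at this position, a 3.7-fold higher number from compound 3 to compound 4 (0.57 log units; beyond the scatter), and so shows that the number responds to what this nitrogen carries. The exchange keeps the count at 3 heavy atoms, while one carbon gives way to one oxygen and 1 hydrogen-bond donor and 1 hydrogen-bond acceptor enter, so a step beyond the scatter appears here without any change in that count. Nothing measured here says why the number rises with this exchange.

A single step cannot separate the loss of isopropyl from the arrival of 2-hydroxyethyl, and the compounds shown leave open how an amine, a carboxylic acid or a longer chain on this nitrogen would read in this assay. Also open, on these data alone, is whether the same exchange would give a step of similar size on a core carrying a methoxy group, as the core of compound 1 does.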